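Aryl swap on a nucleoside core: compound 1 to compound 3

The source may report more compounds than this note shows. Statements on the series, on what has been measured and on what is new or still open speak of the compounds shown alone.

Measured so far:
compound 1 `Nc1nc2c(c(-c3ccccc3)cn2[C@@H]2O[C@H](CO)[C@@H](O)[C@H]2O)c(=O)[nH]1` — > 100000 nM
compound 2 `COc1ncnc2c1c(-c1ccoc1)cn2[C@@H]1O[C@H](CO)[C@@H](O)[C@H]1O` — 1160 nM

In a functional assay on A549 cells (Homo sapiens), read by MTT assay, with a stated time of 72 h (on this read-out higher numbers stand for weaker inhibition and lower numbers for stronger inhibition), compound 1 reaches only a limit, > 100000 nM; it stands at the limit of > 100000 nM in this assay, at which 1 of the 2 values shown sits, so no number is known for it. Within the data shown here, compound 2 in this assay gives 1160 nM; the two compounds differ in several places, so no step between them can be read. Compound 3 `Nc1nc2c(c(-c3ccco3)cn2[C@@H]2O[C@H](CO)[C@@H](O)[C@H]2O)c(=O)[nH]1` differs from compound 1 by furan-2-yl in place of phenyl on an aromatic carbon. The step from compound 1 to compound 3 is expected at an at least 1.6-fold lower number from compound 1 to compound 3 (0.22 log units; that floor lies within the scatter), a move toward stronger inhibition that may not exceed the scatter. Compound 3 is estimated at 60000 nM, with a range from 8000 nM to 100000 nM.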

Compound 3, half-maximal inhibitory concentration: > 20000 nM
Compound 3 gave a limit, no number; the forecaster's own chance of this, stated with the estimate: 55%; the middle value lies beyond the limit too.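

Compound 1 gives only a limit, > 100000 nM. Compound 3 also gives only a limit, > 20000 nM. Among these compounds, no step between compound 1 and compound 3 can therefore be read. As far as these compounds go, whether furan-2-yl in place of phenyl changes inhibition at all remains open.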